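From anilino to amino in compound 1

The compounds below may be only part of what the source reports. "The series", "measured", "known", "first", "only" and "open" are said of these compounds alone.

Compound 1 `CCN(CC)CN1C(=O)/C(=N/NC(=S)Nc2ccccc2)c2cc(Cl)ccc21` gives 40000 nM
Compound 2 `CCN(CC)CN1C(=O)/C(=N/NC(=S)Nc2ccc(Cl)cc2)c2ccccc21` gives 10000 nM

In a functional assay on CCRF-CEM cells (Homo sapiens) for inhibition, read by cell counting, with a stated time of 72 h (on this read-out higher numbers stand for weaker inhibition and lower numbers for stronger inhibition), compound 1 (40000 nM) has the higher of the two numbers, so it is the weaker inhibitor. Compound 2 (10000 nM) lies lower by more than the usual scatter of repeated measurements.

Compound 3 `CCN(CC)CN1C(=O)/C(=N/NC(N)=S)c2cc(Cl)ccc21` keeps the core of compound 1 and changes in one place (hydrogen in place of phenyl on an amide-type nitrogen). It has hydrogen in place of phenyl on an amide-type nitrogen, which reads as anilino to amino. Among the measured compounds shown here, no measured pair shows this change, so the data offer no direct guide to its effect. In this assay the expectation is therefore a step no larger than the scatter, with no firm direction. The estimated step (a 1.3-fold higher number from compound 1 to compound 3 (0.10 log units; within the scatter)) is small. Compound 3 is expected to give about 50000 nM (estimated range 12000 nM to 150000 nM).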

Compound 3, half-maximal inhibitory concentration: 71000 nM
Beside the measured number, compound 3's estimate is 1.4-fold (0.15 log units) below it, and the stated range covers the measured number.
By their numbers in this assay, from the lowest: compound 2; then compounds 1 and 3 (each within the scatter of the next).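

In this assay, among the compounds shown here, replacing phenyl with hydrogen on the amide-type nitrogen gives a 1.8-fold higher number from compound 1 to compound 3 (0.25 log units; within the scatter), the first direct reading of this change. A step of this size cannot be told apart from repeat-measurement noise, so removing the whole six-carbon aromatic ring has no demonstrable effect on the read-out here, and this pair gives no sign that the phenyl contributes to inhibition. Nothing available explains this result.

This single pair cannot show whether the position is insensitive to all substitution or whether phenyl and hydrogen merely happen to give similar numbers. A small methyl, a longer chain such as butyl, or a ring carrying a basic amine, such as a piperidine, on this nitrogen would help separate those two readings.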